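The source may hold more compounds than are shown below. What is called first, only, known or untested is meant among the compounds shown, and "the series" means these compounds.

In a functional assay on NCI-H460 cells (Homo sapiens) for cytotoxicity, read by MTT assay, with a stated time of 72 h (a higher number here means a weaker inhibitor, a lower number a stronger inhibitor), compound 1 `CCCCCCCCNC1=CC(=O)C=C(C[C@]2(C)[C@@H](C)CC[C@]3(C)C(C)=CCC[C@@H]23)C1=O` gives 35000 nM and compound 3 `CCNC1=CC(=O)C(C(C)(C)C)=CC1=O` gives 65000 nM as its value, two numbers within the scatter of each other. Compound 2 `CCCCNC1=CC(=O)C(C[C@]2(C)[C@@H](C)CC[C@]3(C)C(C)=CCC[C@@H]23)=CC1=O` reads > 100000 nM as a limit of the assay, not a number. The change to compound 4 `CNC1=CC(=O)C(C(C)(C)C)=CC1=O` is hydrogen in place of methyl on a saturated chain carbon bound to an amine nitrogen in the form of hydrogen in place of methyl on a saturated chain carbon bound to an amine nitrogen, turning ethylamino into methylamino. Going by the values given here, with compound 3 at 65000 nM as the reference and no measured pair isolating this change, no shift beyond the scatter is expected in this assay here. The estimated 1.1-fold higher number from compound 3 to compound 4 (0.03 log units; within the scatter) therefore stays within the scatter. Compound 4 is expected at 70000 nM with an estimated range from 30000 nM to 100000 nM as its span.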

Compound 4, half-maximal inhibitory concentration: 58000 nM
For compound 4 the middle estimate is 1.2-fold (0.08 log units) above the measured one, within the range that was stated.
By their numbers in this assay, from the lowest: compounds 1, 4 and 3 (each within the scatter of the next). At a limit, above all of these: compound 2.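

In this assay, going by these compounds alone, the change from ethylamino to methylamino gives a 1.1-fold lower number from compound 3 to compound 4 (0.05 log units; within the scatter) and is the first step that isolates a single change. At this saturated chain carbon bound to an amine nitrogen, hydrogen in place of methyl therefore produces no shift beyond the scatter. No measurement shown bears on a cause for this step.

Still open, going by these compounds, is how the core of compound 4 responds when a carboxylic acid or a phenyl group replaces methylamino. A single step also cannot establish a trend along this chain.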